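The source may hold more compounds than are shown below. What is called first, only, known or untested is meant among the compounds shown, and "the series" means these compounds.

Measured in an ADME assay on C2C12 cells (Mus musculus) for cytotoxicity (a higher number here means that more compound is tolerated, a lower number that less compound is tolerated), both values being limits:
- Compound 1 `c1ccc(CNc2nc(Nc3ccccc3)nc3ccccc23)cc1`: > 10000 nM
- Compound 2 `c1ccc(CNc2nc(Nc3nccs3)nc3ccccc23)cc1`: > 10000 nM

In this assay compound 2 stands at > 10000 nM, which is a limit and not a number. Among the measured compounds shown here, it shares that position with the only other compound measured: the limit of > 10000 nM in this assay, at which 2 of the 2 values shown sit.

Compound 3 `Clc1ccc(Nc2nc(NCc3ccccc3)c3ccccc3n2)cc1` carries 4-chlorophenyl in place of 1,3-thiazol-2-yl on a nitrogen on an aromatic ring.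

For the measured compounds named here, the only measured step at that place is a step that the two limits leave unreadable from compound 1 to compound 2, so it gives no direction, and no step beyond the scatter is expected. The expected move is a step that the limit leaves unreadable from compound 2 to compound 3.

For compound 3 the estimated value is 12000 nM, with an expected range of 4000 nM to 40000 nM, and a reading at the limit again is considered likely.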

Compound 3, half-maximal cytotoxic concentration: 10000 nM
Compound 3: the middle estimate sits 1.2-fold (0.08 log units) above what was measured, and the stated range covers the measured number.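

In this assay compound 3, with 4-chlorophenyl on the nitrogen, gives 10000 nM, the first actual number rather than a limit at this position. The values of compound 1 and compound 2 are both limits, so the size of neither step can be read: 4-chlorophenyl in place of 1,3-thiazol-2-yl gives a number no higher from compound 2 to compound 3 (the limit leaves the size open), and chloro in place of hydrogen on the phenyl gives a number no higher from compound 1 to compound 3 (the limit leaves the size open). The set as a whole therefore still rests mostly on limits: the limit of > 10000 nM in this assay, at which 2 of the 3 values shown sit.

From the compounds shown here alone, it remains open whether the chloro group changes tolerance at all, as a real gap to compound 1 cannot be told from these values. Going by these compounds, how a carboxylic acid or an amine in place of the chloro would read in this assay also stays open.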